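The source may hold more compounds than are shown below. What is called first, only, known or untested is meant among the compounds shown, and "the series" means these compounds.

Measured so far in an ADME assay on microsomes from liver (Homo sapiens) for metabolic stability, read by LC-MS, using NADPH, with stated times of 10 min and 45 min, tested at 1 uM; a lower number here means slower removal, a higher number faster removal of the compound:

compound 1 `Cc1cc(C)c(CN2CCc3c(Cl)cc(-c4c(C)noc4C)c(Cl)c3C2=O)c(=O)[nH]1` — 107 uL/min
compound 2 `Cc1cc(C)c(CN2CCc3c(Cl)cc(C(CO)C4CCOC4)c(Cl)c3C2=O)c(=O)[nH]1` — 20 uL/min; 25.9 uL/min (2 entries)
compound 3 `COC(C)c1cc(Cl)c2c(c1Cl)C(=O)N(Cc1c(C)cc(C)[nH]c1=O)CC2` — 190 uL/min; 158 uL/min (2 entries)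

On these numbers, compound 1 sits close to compound 3 and well above compound 2, whose repeated entries the several entries of compound 2 in this assay, 20 uL/min; 25.9 uL/min (2 entries) agree closely, as do those of compound 3 (the several entries of compound 3 in this assay, 190 uL/min; 158 uL/min (2 entries)).

Compound 4 `Cc1cc(C)c(CN2CCc3c(Cl)cc([C@H](CO)[C@H]4CCCO4)c(Cl)c3C2=O)c(=O)[nH]1` has not yet been measured. It differs from compound 1 in one place: a group of 8 heavy atoms (6 carbon, 2 oxygen; one five-membered non-aromatic ring with 1 hetero atom) in place of a group of 7 heavy atoms (5 carbon, 1 nitrogen, 1 oxygen; one five-membered aromatic ring with 2 hetero atoms), on an aromatic carbon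

Compound 4 is expected to be cleared more slowly than compound 1, a step of a 4.3-fold lower number from compound 1 to compound 4 (0.63 log units; beyond the scatter) that would be beyond the usual scatter, because compound 2, which carries a related hydroxymethyl and oxolane group in the same place, gives 20 uL/min; 25.9 uL/min (2 entries). The estimate for compound 4 in this assay is 25 uL/min, ranging from 12 uL/min to 50 uL/min.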

Compound 4, intrinsic clearance in a liver preparation (reported as CLH), per the amount of preparation that the assay uses: 51.6 uL/min
The estimate for compound 4 lay 2.1-fold (0.31 log units) below the measured number; measured number above the stated range.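

In this assay, replacing the aromatic 3,5-dimethyl-1,2-oxazol-4-yl group with the non-aromatic group carrying a hydroxymethyl and an oxolane ring gives a 2.1-fold lower number from compound 1 to compound 4 (0.32 log units; beyond the scatter). Among the compounds shown here, this is the first single-place change that can be read at this aromatic carbon, and it shows that the number responds to the group placed there. Even so, compound 4 at 51.6 uL/min stays higher than both values of the related compound: the several entries of compound 2 in this assay, 20 uL/min; 25.9 uL/min (2 entries)

Which part of the new group, the hydroxymethyl or the oxolane ring, accounts for the step remains open. So does how an amine or a carboxylic acid at this carbon would behave.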